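The compounds below may be only part of what the source reports. "The series", "measured", "known", "first", "only" and "open" are said of these compounds alone.

Compound 2, `Cc1cc(C)c(Oc2nc(Nc3ccc(C#N)cc3)nc3ccccc23)c(C)c1`, belongs to a small set built on one shared core, together with compound 1, `N#Cc1ccc(Nc2nc(Oc3ccc(Cl)cc3Cl)c3ccccc3n2)cc1`, and compound 3, `COc1cc(C#N)cc(Cl)c1Oc1nc(Nc2ccc(C#N)cc2)nc2ccccc12`. In an ADME assay on MT4 cells (Homo sapiens) for cytotoxicity, read by MTT assay, with a stated time of 4 days (a higher number here means that more compound is tolerated, a lower number that less compound is tolerated), compound 1 gives 32000 nM. In this assay compound 3 gives 220000 nM. For compound 2 the picture is less sharp: in this assay compound 2 is recorded only as a limit of the assay, > 34000 nM, not as an exact number. Compound 2 thus sits at the limit of > 34000 nM in this assay, at which 1 of the 3 values shown sits.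

Going by the values given here, only one measured step reaches compound 2: an at least 1.0-fold higher number from compound 1 to compound 2 (0.02 log units; that floor lies within the scatter), with 2,4,6-trimethylphenyl in place of 2,4-dichlorophenyl on an oxygen on an aromatic ring. That step is within the usual scatter and ends at a limit, so it gives little footing.

Compound 4, `Cc1ccccc1Oc1nc(Nc2ccc(C#N)cc2)nc2ccccc12`, carries a smaller group at the same place: 2-methylphenyl in place of 2,4,6-trimethylphenyl on an oxygen on an aromatic ring. Among the compounds with values here, no measured step removes methyl groups from this ring, so the expectation rests on the bare fact that compound 2 sits at a limit and compound 1 sits nearby. Compound 4 is expected to give about 40000 nM in this assay, with a range from 15000 nM to 150000 nM. This expected step, a step that the limit leaves unreadable from compound 2 to compound 4, would stay within the usual scatter.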

Compound 4, half-maximal cytotoxic concentration: 355000 nM
Estimate against measurement, compound 4: 8.9-fold (0.95 log units) below; measured number outside the range, above it.
By their numbers in this assay, from the lowest: compound 1; then compounds 3 and 4 (each within the scatter of the next).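

In this assay, the group on the oxygen now has a measured step of real size: 2-methylphenyl in place of 2,4-dichlorophenyl gives an 11-fold higher number from compound 1 to compound 4 (1.05 log units; beyond the scatter). This shows that a change at this one place, with the rest of the molecule left as it is, can move the tolerated concentration well beyond the scatter, something the earlier step, which stayed within the scatter and ended at a limit, could not show. As far as these compounds go, the step from compound 2 to compound 4 cannot be read, and so the effect of going from 2,4,6-trimethylphenyl to 2-methylphenyl stays unknown, because the value of compound 2 is only a limit: the limit of > 34000 nM in this assay, at which 1 of the 4 values shown sits.

The compounds shown do not separate the loss of the two chlorine atoms from the gain of the methyl group, so it stays open which of these carries the step from the 2,4-dichlorophenyl group to the 2-methylphenyl group. From the compounds shown here alone, it also stays open how this place would respond to a phenyl ring carrying an amine, a carboxylic acid or a longer chain such as propyl.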